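Sulfonamide aryl series: from compound 2 to compound 3

A few compounds are considered here, and "the series" means these few. Any claim that something is new, unique, unknown or untested is made for them only; others in the source may bear on it.

compound 1 `O=S(=O)(Nc1ccc(Cl)c(Cl)c1)c1ccc(-c2cnc(C3CC3)o2)cc1` gives 62100 nM
compound 2 `Cc1cc(Cl)ccc1NS(=O)(=O)c1ccc(-c2cnc(C3CC3)o2)cc1` gives 54700 nM

In a functional assay on cells (leukaemia cell line, Homo sapiens) for inhibition, read by sulforhodamine B assay, with a stated time of 48 h (on this read-out lower numbers stand for stronger inhibition of growth and higher numbers for weaker inhibition of growth), compound 2 gives 54700 nM and stands within the scatter of compound 1, which gives 62100 nM on the same read-out. The two cannot be told apart on these numbers.

Compound 3 `Cc1ccc(Cl)c(NS(=O)(=O)c2ccc(-c3cnc(C4CC4)o3)cc2)c1` carries 2-chloro-5-methylphenyl in place of 4-chloro-2-methylphenyl on a sulfonamide nitrogen, with the same atoms joined differently (2-chloro-5-methylphenyl in place of 4-chloro-2-methylphenyl on a sulfonamide nitrogen) and the shared core unchanged.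

Among the measured compounds shown here, the only measured step at this place is a 1.1-fold lower number from compound 1 to compound 2 (0.06 log units; within the scatter) and it stays within the scatter. For the measured compounds named here, one step is a thin basis, and no measured compound carries the 2-chloro-5-methylphenyl group. Going by the values given here, still, nothing measured so far points to a change of size here. The expected step is a 1.0-fold higher number from compound 2 to compound 3 (0.01 log units; within the scatter) and so none beyond the scatter is expected in this assay for this pair. For compound 3 the estimated value is 56000 nM with an expected range from 28000 nM to 105000 nM on this read-out.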

Compound 3, concentration for total growth inhibition: 52800 nM
Compound 3: the middle estimate sits 1.1-fold (0.03 log units) above what was measured; the range from low to high includes it.
By their numbers in this assay, from the lowest: compounds 3, 2 and 1 (each within the scatter of the next).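

In this assay the step of a 1.0-fold lower number from compound 2 to compound 3 (0.02 log units; within the scatter) comes from 2-chloro-5-methylphenyl in place of 4-chloro-2-methylphenyl on a sulfonamide nitrogen, so this rearrangement of the same atoms is not resolved by this read-out. Among the compounds shown here, the step of a 1.2-fold lower number from compound 1 to compound 3 (0.07 log units; within the scatter) extends that picture to a second comparison with the 3,4-dichlorophenyl group, and all three groups tried at this place now stand within the scatter of one another, whereas the earlier pair gave only one such comparison. No measurement at hand bears on why these groups read alike.

From the compounds shown here alone, all three compounds carry a phenyl group with only chloro or methyl substituents on the sulfonamide nitrogen, so it stays open whether a group of another kind there, such as an amine, a carboxylic acid or a longer alkyl chain, would give a step beyond the scatter. Going by these compounds, it also stays open whether the cyclopropyl group on the shared core matters to this read-out, and whether a replacement such as tert-butyl or a morpholine there would separate the compounds.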